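The compounds below may be only part of what the source reports. "The series", "measured", "known", "first", "only" and "open" are said of these compounds alone.

This account concerns four compounds examined in a functional assay on A549 cells (Homo sapiens), read by MTT assay, with a stated time of 72 h; a lower number here means a stronger inhibitor, a higher number a weaker inhibitor. Compound 1 `O=c1[nH]cnc2c1c(-c1ccoc1)cn2[C@@H]1O[C@H](CO)[C@@H](O)[C@H]1O` and compound 2 `Cc1nc(N)c2c(-c3ccoc3)cn([C@@H]3O[C@H](CO)[C@@H](O)[C@H]3O)c2n1` both carry a furan-3-yl group but sit on different cores; the difference between the two cores is not broken down here. In this assay compound 1 reaches only the limit of the measurement, > 20000 nM. Compound 2 likewise gives only a limit in this assay, > 20000 nM. Compound 3 `O=c1[nH]cnc2c1c(-c1cc3ccccc3o1)cn2[C@@H]1O[C@H](CO)[C@@H](O)[C@H]1O` is derived from compound 1 by one change, (1-benzofuran-2-yl in place of furan-3-yl on an aromatic carbon). In this assay compound 3 also stops at the limit, > 20000 nM. The step that the two limits leave unreadable from compound 1 to compound 3 therefore cannot be sized, because the limit of > 20000 nM in this assay, at which 3 of the 3 values shown sit, holds for both of its ends.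

Compound 4 `Cc1nc(N)c2c(-c3cc4ccccc4o3)cn([C@@H]3O[C@H](CO)[C@@H](O)[C@H]3O)c2n1` has not yet been measured. It stands to compound 2 exactly as compound 3 stands to compound 1, through (1-benzofuran-2-yl in place of furan-3-yl on an aromatic carbon), and the surroundings of the change are the same in both pairs, so it is the same change made a second time. Within the data shown here, since the first instance of this change left its result unreadable, the second instance gives no reason to expect a number inside the measurable range. The expected step that the limit leaves unreadable from compound 2 to compound 4 is therefore small or unreadable, and this expectation rests on (the limit of > 20000 nM in this assay, at which 3 of the 3 values shown sit), the common limit at which compound 1, compound 2 and compound 3 all sit. Compound 4 is accordingly expected to give about 30000 nM, with a plausible range from 8000 nM to 200000 nM, most likely again reported only as a limit.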

Compound 4, half-maximal inhibitory concentration: > 20000 nM
Compound 4 gave a limit, no number (the forecaster's own chance of this, stated with the estimate: 85%); the middle value does not contradict the limit.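

In this assay compound 4 gives > 20000 nM, which is a limit and not a number. Compound 2 also sits at a limit, so no size can be read for the exchange between compound 2 and compound 4: the limit of > 20000 nM in this assay, at which 4 of the 4 values shown sit.

The compounds shown leave open how strongly any of the four inhibits, and whether 1-benzofuran-2-yl in place of furan-3-yl changes that strength on either core.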